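A few compounds are considered here, and "the series" means these few. Any claim that something is new, unique, unknown or untested is made for them only; others in the source may bear on it.

Measured so far:
- compound 1 `COc1ccc(-c2cc(C(=O)Nc3nc4ccc(Cl)cc4s3)nc3cc(-c4ccccc4)nn23)cc1OC`: 7760 nM
- compound 2 `O=C(Nc1nc2ccc(F)cc2s1)c1cc(-c2ccc(F)cc2)n2nc(-c3ccccc3)cc2n1`: 35500 nM
- compound 3 `COc1ccc(-c2cc(C(=O)Nc3nc4ccc(F)cc4s3)nc3cc(-c4ccccc4)nn23)cc1`: 39300 nM

In a functional assay on ACHN cells (Homo sapiens) for cytotoxicity, read by MTT assay, with a stated time of 48 h (a lower number here means a stronger inhibitor, a higher number a weaker inhibitor), compound 3 gives the highest of the three numbers; against compound 2 the gap is within the scatter, while compound 1 sits well lower. Going by the values given here, the one measured step, a 1.1-fold higher number from compound 2 to compound 3 (0.04 log units; within the scatter), swaps groups on the same ring that the present change concerns and moves nothing beyond the scatter.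

Compound 4 `COc1ccc(-c2cc(C(=O)Nc3nc4ccc(F)cc4s3)nc3cc(-c4ccccc4)nn23)cc1OC` is compound 3 with methoxy in place of hydrogen on an aromatic carbon. Among the compounds with values here, no measured step adds a group at this place, so the step cannot be read from a like pair. Within the data shown here, compound 1 is the only other compound carrying the two methoxy groups and gives the lowest number, but it also differs from compound 4 on the other ring, so its value only hints at the direction. A modest move to a lower number is therefore expected for compound 4, a 2.5-fold lower number from compound 3 to compound 4 (0.39 log units; beyond the scatter), with wide uncertainty. The estimate for compound 4 in this assay is 16000 nM, ranging from 5000 nM to 45000 nM.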

Compound 4, half-maximal inhibitory concentration: 8120 nM
The estimate for compound 4 lay 2.0-fold (0.29 log units) above the measured number; the measured number falls inside the stated range.
By their numbers in this assay, from the lowest: compounds 1 and 4 (each within the scatter of the next); then compounds 2 and 3 (each within the scatter of the next).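

In this assay, going by these compounds alone, the change from 4-methoxyphenyl to 3,4-dimethoxyphenyl gives a 4.8-fold lower number from compound 3 to compound 4 (0.68 log units; beyond the scatter) and is the first change on this ring to pass beyond the scatter, while 3,4-dimethoxyphenyl in place of 4-fluorophenyl gives a 4.4-fold lower number from compound 2 to compound 4 (0.64 log units; beyond the scatter) on the same ring. With 3,4-dimethoxyphenyl held constant, fluoro in place of chloro on the other ring gives a 1.0-fold higher number from compound 1 to compound 4 (0.02 log units; within the scatter) and so leaves the number unchanged within the scatter. No measurement on hand accounts for these steps.

As far as these compounds go, it remains open whether the added methoxy needs the existing methoxy group to give this step. Also open, from the compounds shown here alone, is whether a hydroxy group, an amine or a longer alkoxy chain on the same aromatic carbon would give a comparable number.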